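Aryl for Isopropyl on the Amide-Type Nitrogen

A few compounds are considered here, and "the series" means these few. Any claim that something is new, unique, unknown or untested is made for them only; others in the source may bear on it.

In a functional assay on HepG2 cells (Homo sapiens) for antiproliferative activity, read by MTT assay, with a stated time of 72 h (on this read-out lower numbers stand for stronger inhibition and higher numbers for weaker inhibition), compound 3 `CC(C)N1C(=O)COc2ccc(-c3cccc(NS(=O)(=O)c4ccc(F)cc4)c3)cc21` gives only a limit, > 40000 nM, which is the limit of > 40000 nM in this assay, at which 1 of the 3 values shown sits. Compound 1 `O=C1COc2ccc(-c3cnc(Cl)c(NS(=O)(=O)c4ccc(F)cc4)c3)cc2N1c1ccc(Cl)cc1` gives 33900 nM, and compound 2 `Cc1ccc(N2C(=O)COc3ccc(-c4cnc(Cl)c(NS(=O)(=O)c5ccc(F)cc5)c4)cc32)cc1` gives 39600 nM; both carry an aryl group on the amide-type nitrogen, though they differ from compound 3 in a second place as well. Going by the values given here, the only measured step, a 1.2-fold higher number from compound 1 to compound 2 (0.07 log units; within the scatter), alters that aryl group alone and does not bear directly on the move to compound 4 `COc1ccc(N2C(=O)COc3ccc(-c4cccc(NS(=O)(=O)c5ccc(F)cc5)c4)cc32)cc1`, which differs from compound 3 as follows: 4-methoxyphenyl in place of isopropyl on an amide-type nitrogen in a ring. Among the compounds with values here, with compound 3 at a limit, no measured step sets the size of this change, and compound 4 is expected to land near the values of compounds 1 and 2. Compound 4 is therefore estimated at 40000 nM, within 15000 nM to 120000 nM. The expected step of a number no higher from compound 3 to compound 4 (the limit leaves the size open) cannot be placed beyond the scatter.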

Compound 4, half-maximal inhibitory concentration: 29800 nM
Compound 4: the middle estimate sits 1.3-fold (0.13 log units) above what was measured; low and high end bracket the measured number.
By their numbers in this assay, from the lowest: compounds 4, 1 and 2 (each within the scatter of the next). At a limit, above all of these: compound 3.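

In this assay, 4-methoxyphenyl in place of isopropyl on the amide-type nitrogen in the ring gives an at least 1.3-fold lower number from compound 3 to compound 4 (0.12 log units; that floor lies within the scatter). This position therefore accepts an aromatic ring on the core of compound 3 and yields a measured number rather than a limit. The true size of the step stays unknown because compound 3 is held at a limit: the limit of > 40000 nM in this assay, at which 1 of the 4 values shown sits.

Going by these compounds, whether an amine or a carboxylic acid on this nitrogen would move the number beyond the scatter remains open. So does the effect of a longer chain in place of isopropyl.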